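The compounds below may be only part of what the source reports. "The series", "measured", "known", "first", "only" and "open" are said of these compounds alone.

In a functional assay on A549 cells (Homo sapiens) for antiproliferative activity, read by MTT assay, with a stated time of 72 h (on this read-out lower numbers stand for stronger inhibition and higher numbers for weaker inhibition), three compounds have been measured so far. Compound 1 `COc1ccc(-c2cc3[nH]nc(-c4cc(OC)c(OC)c(OC)c4)n3n2)cc1[N+](=O)[O-]` gives 58200 nM. For the measured compounds named here, compound 2 `COc1ccc(-c2cc3[nH]nc(-c4cc(OC)c(OC)c(OC)c4)n3n2)cc1N` gives 17400 nM, and the one change between the two is a 3.3-fold lower number from compound 1 to compound 2 (0.52 log units; beyond the scatter), amino in place of nitro on an aromatic carbon. Compound 3 `COc1ccc(-c2nnc3sc(-c4ccc(C)cc4)nn23)c(OC)c1OC` gives 803 nM, the lowest of the three numbers, and its distance to each of the other two lies beyond the scatter. Compound 4 `COc1ccc(-c2nn3c(-c4ccc(OC)c(OC)c4OC)nnc3s2)cc1N` has not yet been measured in this assay. It differs from compound 3 in one place: 3-amino-4-methoxyphenyl in place of 4-methylphenyl on an aromatic carbon. Going by the values given here, no measured step covers this exact exchange. Among the compounds with values here, the one measured step concerns only the amino group of the same 3-amino-4-methoxyphenyl on a different core, and it was modest. Compounds 1 and 2, which carry that group, give far higher numbers than compound 3, but their core differs too, so that gap says little on its own. A small step is therefore expected, a 1.9-fold higher number from compound 3 to compound 4 (0.27 log units; within the scatter), leaning toward a higher number. Compound 4 is estimated at 1500 nM, with a range from 400 nM to 6000 nM.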

Compound 4, half-maximal inhibitory concentration: 82 nM
Compound 4: middle estimate off by 18-fold (1.26 log units), on the high side; the measured number lies below the stated range.
By their numbers in this assay, from the lowest: compound 4; then compound 3; then compound 2; then compound 1.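

Placing 3-amino-4-methoxyphenyl in place of 4-methylphenyl on this aromatic carbon, next to the ring sulfur and the ring nitrogen, gives a 9.8-fold lower number from compound 3 to compound 4 (0.99 log units; beyond the scatter) in this assay. This shows that the position accepts a ring carrying more than a small hydrocarbon group, and that the number falls rather than merely holding steady, though this rests on a single pair of compounds. No measured evidence at hand accounts for the size of this step.

As far as these compounds go, whether 3-aminophenyl without the methoxy, or 4-methoxyphenyl without the amino, would keep the lower number stays open, so the two parts of the entering group cannot yet be told apart. Also open, from the compounds shown here alone, is whether the change from nitro to amino seen on the core of compound 1 would carry over to the core shared by compound 3 and compound 4.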